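Swapping a Flexible Side Chain for a Bicyclic Amine

A few compounds are considered here, and "the series" means these few. Any claim that something is new, unique, unknown or untested is made for them only; others in the source may bear on it.

Measured so far:
- compound 1, `Cc1nc(N2CCC(O)(C3CC3)CC2)nc2ccc(NC(=O)COc3ccc(OC(F)(F)F)cc3)cc12`: 36%
- compound 2, `Cc1nc(NCCNC(=O)C2CC2)nc2ccc(NC(=O)/C=C/c3ccc(OC(F)(F)F)cc3)cc12`: 38%

Both compounds were tested in an ADME assay on microsomes from liver (Mus musculus) for metabolic stability, with a stated time of 30 min; a higher number here means that more of the compound is left, a lower number that less of the compound is left. Compound 2 gives the higher of the two numbers, 38%, but its distance from compound 1 is within the usual scatter, so the two values cannot be told apart. Among the compounds with values here, no step between a pair of measured compounds has been worked out here, so there is no measured precedent for any single change.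

Compound 3, `Cc1nc(N2CCC(N3CCNC3=O)CC2)nc2ccc(NC(=O)/C=C/c3ccc(OC(F)(F)F)cc3)cc12`, is the unmeasured one. It is derived from compound 2 by a change on the shared core: 4-(2-oxoimidazolidin-1-yl)piperidin-1-yl in place of (2-((cyclopropylcarbonyl)amino)ethyl)amino on an aromatic carbon. The change is not small, and the two measured compounds offer no guidance on how this assay responds to it. Given that both measured values sit close together, the expectation is a step from compound 2 to compound 3 of a number 3 percentage points lower from compound 2 to compound 3 (within the scatter), that is, no change beyond the scatter. Compound 3 is therefore expected to give about 35% in this assay, with a range from 15% to 60%, the wide span reflecting how little is known about this kind of change.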

Compound 3, percent of the compound remaining: 89%
Beside the measured number, compound 3's estimate is 54 percentage points below it, and the stated range ends below it.
By their numbers in this assay, from the lowest: compounds 1 and 2 (each within the scatter of the next); then compound 3.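

In this assay, putting 4-(2-oxoimidazolidin-1-yl)piperidin-1-yl in place of (2-((cyclopropylcarbonyl)amino)ethyl)amino, on the aromatic carbon between two ring nitrogen atoms, gives a number 51 percentage points higher from compound 2 to compound 3 (beyond the scatter). Within the data shown here, this is the first measured sign that the group at this position can strongly shift how much compound is left, something the first two compounds could not show, as they differ in more than one place and their values lie within the scatter of each other. The swap changes several things at once, replacing an open chain and its three-membered ring with two linked non-aromatic rings, and nothing available here explains the size of the step.

From the compounds shown here alone, it remains open which part of the new group goes with the higher number, for instance whether a piperidin-1-yl ring carrying a plain amine in place of the 2-oxoimidazolidin-1-yl ring would behave like compound 3. Among these compounds, it is also open whether the same group gives a similar step on a compound with the other amide side chain, the one found in compound 1.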